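Swapping the propynyl amine of compound 1 for isopropyl

A few compounds are considered here, and "the series" means these few. Any claim that something is new, unique, unknown or untested is made for them only; others in the source may bear on it.

Compound 1 `CN1CCN(CC#Cc2cc3ncnc(Nc4ccc(OCc5cccc(F)c5)c(Cl)c4)c3s2)CC1` sits lowest of the two numbers in an ADME assay on HepG2 cells (Homo sapiens) for cytotoxicity (a higher number here means that more compound is tolerated, a lower number that less compound is tolerated), giving 11 uM. Compound 2 `CC(C)(C)CC#Cc1cc2ncnc(Nc3ccc(OCc4cccc(F)c4)c(Cl)c3)c2s1` gives 29.3 uM, a step of a 2.7-fold higher number from compound 1 to compound 2 (0.43 log units; beyond the scatter). Compound 3 `CN(C)CC#Cc1cc2ncnc(Nc3ccc(OCc4cccc(F)c4)c(Cl)c3)c2s1` reaches only a limit of the assay, > 32 uM. The step of an at least 2.9-fold higher number from compound 1 to compound 3 (0.46 log units; beyond the scatter) is read against (the limit of > 32 uM in this assay, at which 1 of the 3 values shown sits). Compound 4 `CC(C)CC#Cc1cc2ncnc(Nc3ccc(OCc4cccc(F)c4)c(Cl)c3)c2s1` differs from compound 1 by isopropyl in place of 4-methylpiperazin-1-yl on a saturated chain carbon bound to a triple-bonded carbon. Among the measured compounds shown here, the change most like it is the one to compound 2, where tert-butyl also replaced the same group; that step and the one to compound 3 both moved the number up beyond the scatter, so a modest rise is expected here too. For compound 4 the expected value is 25 uM, within 12 uM to 50 uM, an estimated step of a 2.3-fold higher number from compound 1 to compound 4 (0.36 log units; beyond the scatter).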

Compound 4, half-maximal toxic concentration: > 32 uM
Compound 4: no number, only a limit; the forecaster's own chance of this, stated with the estimate: 25%; middle value at least 1.2-fold (0.10 log units) away from the limit.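

In this assay, isopropyl in place of 4-methylpiperazin-1-yl gives an at least 2.9-fold higher number from compound 1 to compound 4 (0.46 log units; beyond the scatter), so a third replacement on this saturated chain carbon moves the same way, and no listed replacement goes against this. Removing one methyl from tert-butyl gives an at least 1.0-fold higher number from compound 2 to compound 4 (0.03 log units; that floor lies within the scatter), which leaves that change unresolved. Compound 4 stands at a limit of the assay, as compound 3 does, and the step between them cannot be read: the limit of > 32 uM in this assay, at which 2 of the 4 values shown sit.

Where compound 3 and compound 4 truly lie beyond that limit stays open. Going by these compounds, whether the lower number of compound 1 follows the ring or its nitrogens also stays open, and piperidin-1-yl or morpholin-4-yl on the same carbon would bear on that.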